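A few compounds are considered here, and "the series" means these few. Any claim that something is new, unique, unknown or untested is made for them only; others in the source may bear on it.

compound 1 `COc1cccc(/C=C/C(=O)c2ccc(OC)c3c2OC(C)(C)C=C3)c1`: > 10000 nM
compound 2 `COc1ccc(C(=O)/C=C/c2ccc(Br)cc2)c2c1C=CC(C)(C)O2`: > 10000 nM
compound 3 `COc1ccc(C(=O)/C=C/c2ccc(Cl)cc2)c2c1C=CC(C)(C)O2`: > 10000 nM

In a functional assay on HT-29 cells (Homo sapiens) for antiproliferative activity, read by MTT assay, with a stated time of 24 h (a higher number here means a weaker inhibitor, a lower number a stronger inhibitor), compound 3 stands at > 10000 nM, which is a limit and not a number. Going by the values given here, the series so far offers only (the limit of > 10000 nM in this assay, at which 3 of the 3 values shown sit). Compound 4 `COc1ccc(C(=O)/C=C/c2ccccc2Cl)c2c1C=CC(C)(C)O2` differs from compound 3 in one group: 2-chlorophenyl in place of 4-chlorophenyl on a double-bonded chain carbon bound to a double-bonded chain carbon. Among the compounds with values here, two measured steps bear on this change: a step that the two limits leave unreadable from compound 1 to compound 3 and a step that the two limits leave unreadable from compound 2 to compound 3. Neither gives a size or a direction, so no step beyond the scatter is expected, and compound 4 may again return only a limit. The estimated step is a step that the limit leaves unreadable from compound 3 to compound 4. In this assay, compound 4 is expected near 15000 nM, with an estimated range from 6000 nM to 40000 nM.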

Compound 4, half-maximal inhibitory concentration: > 10000 nM
Compound 4 ended at the assay's limit (the forecaster's own chance of this, stated with the estimate: 75%); the middle value is on the limit's open side.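

In this assay compound 4 gives > 10000 nM, a limit and not a number, and its steps from compound 1, compound 2 and compound 3 cannot be read. The compounds shown leave open whether changing the group on the double-bonded chain carbon alters activity at all, as all of them share one limit: the limit of > 10000 nM in this assay, at which 4 of the 4 values shown sit.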